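Swapping Methyl for 4-Fluorophenyl: Expected Microsomal Stability

The compounds below may be only part of what the source reports. "The series", "measured", "known", "first", "only" and "open" are said of these compounds alone.

Three compounds have been measured in an ADME assay on microsomes from liver (Homo sapiens), read by LC-MS, using NADPH, with a stated time of 30 min, tested at 1 uM; a higher number here means that more of the compound is left, a lower number that less of the compound is left:

Compound 1, `Cc1nc(N)nc(N[C@@H](C)c2cc3ccc(F)cn3c(=O)c2-c2ccccc2)c1C#N`, gives 83%.
Compound 2, `C[C@H](Nc1nc(N)nc(N)c1C#N)c1c(-c2ccccc2)c(=O)n2cc(F)ccc2c1-c1ccc(F)cc1`, gives 87%.
Compound 3, `Cc1nc(N)nc(N[C@@H](C)c2c(-c3ccccc3)c(=O)n3cc(F)ccc3c2C)c1C#N`, gives 96%.

Compound 3 stands highest of the three numbers in this assay. Its nearest neighbour is compound 2, which lies within the scatter of it, while compound 1 lies beyond the scatter below it. Among the measured compounds shown here, the only measured step that differs in one place is a number 13 percentage points higher from compound 1 to compound 3 (beyond the scatter), a modest gain that goes with a methyl in place of hydrogen on an aromatic carbon.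

Compound 4, `Cc1nc(N)nc(N[C@@H](C)c2c(-c3ccccc3)c(=O)n3cc(F)ccc3c2-c2ccc(F)cc2)c1C#N`, has not yet been measured. It differs from compound 3 by 4-fluorophenyl in place of methyl on an aromatic carbon. For the measured compounds named here, no measured step in this assay covers this exact exchange, so the step from methyl to hydrogen offers no direct guide. The closest point of comparison is compound 2, which already carries the 4-fluorophenyl at this position and gives 87%, a number within the scatter of compound 3. Compound 4 is therefore expected to give about 88% in this assay, with a likely range from 75% to 98%. The estimated step of a number 8 percentage points lower from compound 3 to compound 4 (within the scatter) is expected to stay within the usual scatter.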

Compound 4, percent of the compound remaining: 91%
Compound 4: the middle estimate sits 3 percentage points below what was measured; low and high end bracket the measured number.
By their numbers in this assay, from the lowest: compounds 1, 2, 4 and 3 (each within the scatter of the next, the first and the last beyond it).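

In this assay, the aromatic carbon two atoms from the ring nitrogen can carry a much larger group than methyl without a clear shift in the number: a number 5 percentage points lower from compound 3 to compound 4 (within the scatter), although the entering 4-fluorophenyl brings a six-membered aromatic ring and 7 heavy atoms in place of 1. Against the hydrogen of compound 1, the picture is less clear than methyl alone suggested, since the methyl step lay beyond the scatter, whereas with 4-fluorophenyl there is a number 8 percentage points higher from compound 1 to compound 4 (within the scatter), so a gain over hydrogen cannot be claimed for this larger group. With 4-fluorophenyl in place, the exchange at the other site also gives no clear shift, with a number 4 percentage points higher from compound 2 to compound 4 (within the scatter) for methyl in place of amino on an aromatic carbon. Nothing else at hand explains why these steps are small.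

As far as these compounds go, it remains open how a plain phenyl, an ethyl chain or a carboxylic acid would behave at this position. From the compounds shown here alone, it is also open whether the methyl and amino exchange would stay this small with hydrogen or methyl at that position instead of 4-fluorophenyl.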